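Replacing a Chloropyridinyl Amide with a Chlorophenyl Amide

The source may report more compounds than this note shows. Statements on the series, on what has been measured and on what is new or still open speak of the compounds shown alone.

Compound 3 `O=C(CCl)Nc1ccc(SCC(=O)Nc2cc(Cl)ccn2)cc1` carries the highest of the two numbers recorded in a functional assay on NCI-H460 cells (Homo sapiens) for antiproliferative activity, read by MTT assay, with a stated time of 48 h (on this read-out lower numbers stand for stronger inhibition and higher numbers for weaker inhibition), where compound 3 gives 5600 nM. Its nearest neighbour, compound 2 `O=C(CCl)Nc1ccc(SCC(=O)Nc2ccc(Br)cn2)cc1`, gives 530 nM. Compound 1 `COc1ccccc1C(=O)Nc1nnc(SCC(=O)Nc2ccc(C)cn2)s1` reaches only a limit of the assay, > 80000 nM. Within the data shown here, the single step measured in one place is an 11-fold higher number from compound 2 to compound 3 (1.02 log units; beyond the scatter). Compound 4 `O=C(CCl)Nc1ccc(SCC(=O)Nc2ccc(Cl)cc2)cc1` differs from compound 3 by 4-chlorophenyl in place of 4-chloropyridin-2-yl on an amide-type nitrogen. Among the measured compounds shown here, no measured step exchanges a 4-chloropyridin-2-yl group for a 4-chlorophenyl group, so the measured step between compound 2 and compound 3 concerns a different change and offers no direct guide. The expected size of the step is therefore a 1.4-fold lower number from compound 3 to compound 4 (0.15 log units; within the scatter), a change not clearly beyond the scatter. Compound 4 is estimated at 4000 nM, within 1000 nM to 20000 nM.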

Compound 4, half-maximal inhibitory concentration: 23100 nM
Compound 4: middle estimate off by 5.8-fold (0.76 log units), on the low side; measured number above the stated range.
By their numbers in this assay, from the lowest: compound 2; then compound 3; then compound 4. At a limit, above all of these: compound 1.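

In this assay, the ring nitrogen matters on this amide-type nitrogen: 4-chlorophenyl in place of 4-chloropyridin-2-yl keeps the chlorine yet gives a 4.1-fold higher number from compound 3 to compound 4 (0.62 log units; beyond the scatter). The earlier step compared two pyridinyl groups only, and with the carbon-only ring the span grows to a 44-fold higher number from compound 2 to compound 4 (1.64 log units; beyond the scatter). Nothing measured here accounts for this rise.

Still open, going by these compounds, is how a 5-chloropyridin-2-yl group would read, which would separate the halogen from its place on the ring. On these data alone, a pyrimidin-2-yl ring on the same nitrogen is equally open.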